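The source may hold more compounds than are shown below. What is called first, only, known or untested is meant among the compounds shown, and "the series" means these compounds.

Measured so far in an ADME assay on cells (Hepatocyte, Mus musculus) for metabolic stability, read by LC-MS, with a stated time of 180 min, tested at 1 uM; on this read-out lower numbers stand for slow clearance and higher numbers for fast clearance:

compound 1 `O=C(O)Cn1nc(Cc2nc3cc(Cl)c(OCC(F)F)cc3[nH]2)c2ccccc2c1=O`: < 28.4 mL/min/kg
compound 2 `CCC(C(=O)O)c1nn(Cc2cn3cc(OCC4CC4)c(Cl)cc3n2)c2ccccc2c1=O`: 155 mL/min/kg
compound 3 `CC(C(=O)O)c1nn(Cc2cn3cc(OCC4CC4)c(C(F)(F)F)cc3n2)c2ccccc2c1=O`: 71.7 mL/min/kg

The value for compound 1 is a limit of this assay rather than a number. Among the two actual numbers, compound 2 stands highest; the nearer of them, from compound 3, is lower by a margin that lies beyond the usual scatter of repeated measurements.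

Compound 4 `O=C(O)Cc1nn(Cc2cn3cc(OCC4CC4)c(Cl)cc3n2)c2ccccc2c1=O` has not yet been measured in this assay. It differs from compound 2 in a single place: hydrogen in place of ethyl on a saturated chain carbon bound to an aromatic carbon and a carbonyl carbon. For the measured compounds named here, no pair of measured compounds differs by this change alone, so its effect cannot be read off directly and has to be expected. Compound 1 also carries a carboxymethyl group, and it sits at the limit of < 28.4 mL/min/kg in this assay, at which 1 of the 3 values shown sits. On that basis the step from compound 2 to compound 4 is expected to run toward slower clearance, by a 3.1-fold lower number from compound 2 to compound 4 (0.49 log units; beyond the scatter), a move likely larger than the scatter. Compound 4 is therefore expected to give about 50 mL/min/kg in this assay, within a range from 20 mL/min/kg to 120 mL/min/kg.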

Compound 4, clearance: 30 mL/min/kg
Compound 4: the middle estimate sits 1.7-fold (0.22 log units) above what was measured, within the range that was stated.
By their numbers in this assay, from the lowest: compound 4; then compound 3; then compound 2. At a limit, below all of these: compound 1.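

In this assay, for the compounds shown here, replacing the ethyl with hydrogen, so that 1-carboxypropyl becomes carboxymethyl, gives a 5.2-fold lower number from compound 2 to compound 4 (0.71 log units; beyond the scatter) and this is the first direct reading of a single change. It shows that the group on this saturated chain carbon, bound to an aromatic carbon and a carbonyl carbon, can by itself shift clearance, with the unsubstituted carbon on the slower side in this pair. Compound 1 also carries a carboxymethyl group but differs from compound 4 in more than one place, and its result is a limit rather than a number: the limit of < 28.4 mL/min/kg in this assay, at which 1 of the 4 values shown sits.

Still open, on these data alone, is how a lone methyl, a propyl chain or a hydroxyl group on this same carbon would compare on the core of compound 4. Also open, as far as these compounds go, is whether the ethyl-to-hydrogen step would keep its size with trifluoromethyl in place of the chlorine.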